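Nitro for fluoro on the aryl ring

A few compounds are considered here, and "the series" means these few. Any claim that something is new, unique, unknown or untested is made for them only; others in the source may bear on it.

compound 1 `OC1CCN(c2ccc(-c3ccccc3)nn2)CC1` gives 83 mg/kg
compound 2 `OC1CCN(c2ccc(-c3ccccc3F)nn2)CC1` gives 30 mg/kg
compound 3 `O=[N+]([O-])c1ccccc1-c1ccc(N2CCC(O)CC2)nn1` is not yet measured

For the measured compounds named here, in a functional assay on the whole organism with Mus musculus as the target (on this read-out higher numbers stand for an effect only at larger amounts of compound and lower numbers for an effect already at smaller amounts), compound 2 holds the lower of the two numbers so far, at 30 mg/kg. The next change leads to compound 3: nitro in place of fluoro on an aromatic carbon This puts nitro in place of fluoro on an aromatic carbon, ortho to a large group. Going by the values given here, only one measured step bears on this change: a 2.8-fold lower number from compound 1 to compound 2 (0.44 log units; beyond the scatter). It involves fluoro and hydrogen only, and no measured compound carries nitro, so the size of this exchange is not shown directly. A modest step of similar size is expected in this assay, leaning slightly towards a higher number, although the direction remains uncertain. The estimated change is a 1.3-fold higher number from compound 2 to compound 3 (0.10 log units; within the scatter). For compound 3 the expected value is 38 mg/kg, with an estimated range from 14 mg/kg to 100 mg/kg.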

Compound 3, dose for half-maximal effect: 81 mg/kg
Estimate against measurement, compound 3: 2.1-fold (0.33 log units) below, and the stated range covers the measured number.
By their numbers in this assay, from the lowest: compound 2; then compounds 3 and 1 (each within the scatter of the next).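

In this assay, the position ortho to a large group does not respond to every replacement of hydrogen in the same way: changing fluoro to nitro gives a 2.7-fold higher number from compound 2 to compound 3 (0.43 log units; beyond the scatter). Nitro in place of hydrogen gives a 1.0-fold lower number from compound 1 to compound 3 (0.01 log units; within the scatter), so compound 1 and compound 3 cannot be told apart, and among these three compounds only fluoro, in compound 2, is linked to a lower number. Nothing available here explains why fluoro and nitro differ at this position.

The compounds shown leave open whether the lower number is peculiar to fluoro or would also appear with another small group at this place, such as chloro, methyl or methoxy. They also leave open how an amine or a carboxylic acid would behave there, and whether fluoro would give a similar step at another carbon of the same ring.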